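The source may hold more compounds than are shown below. What is called first, only, known or untested is meant among the compounds shown, and "the series" means these compounds.

Compound 3 `CCCCn1cc(COc2cc(O)c3c(c2)O[C@H](c2ccc(OC)c(O)c2)C/C3=N\O)nn1` is one of three chalcone-derived oximes that share a core and differ only in the group on the saturated chain carbon bound to the ring oxygen. In a functional assay on RAW264.7 cells (Mus musculus) for inhibition, read by Griess assay, with stated times of 2 h and 24 h (on this read-out higher numbers stand for weaker inhibition and lower numbers for stronger inhibition), compound 3 gives 8900 nM, the second highest of the three numbers. The nearest is compound 2 `COc1ccc([C@@H]2C/C(=N\O)c3c(O)cc(OCc4cn(Cc5ccccc5F)nn4)cc3O2)cc1O`, which in this assay gives 5710 nM; the furthest is compound 1 `C#CCOc1cc(O)c2c(c1)O[C@H](c1ccc(OC)c(O)c1)C/C2=N\O`, which in this assay gives 19100 nM. The two measured steps are a 2.1-fold lower number from compound 1 to compound 3 (0.33 log units; beyond the scatter) and a 1.6-fold higher number from compound 2 to compound 3 (0.19 log units; within the scatter).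

Compound 4 `CCCn1cc(COc2cc(O)c3c(c2)O[C@H](c2ccc(OC)c(O)c2)C/C3=N\O)nn1` is not yet measured. It differs from compound 3 by hydrogen in place of methyl on a saturated chain carbon, three bonds along the chain from an aromatic nitrogen, so the same difference read one bond further out is butyl to propyl. Of the two known steps only the change on the chain bound to the aromatic nitrogen bears on this, and that step, a 1.6-fold higher number from compound 2 to compound 3 (0.19 log units; within the scatter), stayed within the scatter even though it swapped an aromatic group for an alkyl one. Shortening the chain by one carbon is a smaller change still, so no step beyond the scatter is expected in this assay. The expected step is a 1.1-fold higher number from compound 3 to compound 4 (0.03 log units; within the scatter), and compound 4 is estimated to give 9500 nM in this assay, with a range of 4500 nM to 20000 nM.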

Compound 4, half-maximal inhibitory concentration: 2340 nM
Compound 4: middle estimate off by 4.1-fold (0.61 log units), on the high side, and the stated range ends above it.
By their numbers in this assay, from the lowest: compound 4; then compounds 2 and 3 (each within the scatter of the next); then compound 1.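

In this assay, the chain on the aromatic nitrogen proved sensitive to a single carbon: going from butyl to propyl gave a 3.8-fold lower number from compound 3 to compound 4 (0.58 log units; beyond the scatter), whereas the earlier swap of 2-fluorophenyl for propyl at the chain carbon bound to that nitrogen had given only a 1.6-fold higher number from compound 2 to compound 3 (0.19 log units; within the scatter). The propyl chain also separates compound 4 from both other compounds, with a 2.4-fold lower number from compound 2 to compound 4 (0.39 log units; beyond the scatter) and an 8.2-fold lower number from compound 1 to compound 4 (0.91 log units; beyond the scatter), which makes compound 4 the strongest inhibitor of the four, while compound 3 could not be separated from compound 2. The data shown offer no measurement that would explain why removing this one carbon matters so much.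

With only propyl and butyl as straight alkyl chains on the aromatic nitrogen, the compounds shown leave open whether the numbers would keep falling with an ethyl or methyl group or rise again with a pentyl or longer chain. They also leave open how a branched isopropyl group, or a hydroxyl or an amine at the end of the propyl chain, would read in this assay.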